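The source may report more compounds than this note shows. Statements on the series, on what has been measured and on what is new or still open speak of the compounds shown alone.

Measured in an ADME assay on BJ cells (Homo sapiens) for cytotoxicity, with a stated time of 72 h; on this read-out higher numbers stand for an effect only at larger amounts of compound and lower numbers for an effect already at smaller amounts: compound 1 `CCc1ccc(-c2nc3c(c(C)nn3-c3ccccc3)c(-c3ccccc3Br)c2C#N)cc1`, compound 2 `Cc1nn(-c2ccccc2)c2nc(-c3ccc(C(C)C)cc3)c(C#N)c(-c3ccccc3O)c12`.

For compound 1 the result is a limit of this assay, > 20000 nM; (the limit of > 20000 nM in this assay, at which 1 of the 2 values shown sits). In this assay compound 2 gives 22600 nM, the only number shown. Compound 3 `Cc1nn(-c2ccccc2)c2nc(-c3ccc4c(c3)OCCO4)c(C#N)c(-c3ccccc3O)c12` differs from compound 2 by 2,3-dihydro-1,4-benzodioxin-6-yl in place of 4-isopropylphenyl on an aromatic carbon. Within the data shown here, no measured step covers this change in this assay; compound 1 and compound 2 show only that both sit at the top of the range. The step of a 1.1-fold higher number from compound 2 to compound 3 (0.04 log units; within the scatter) is expected to stay within the scatter, with no clear direction. Compound 3 is estimated at 25000 nM, between 10000 nM and 60000 nM.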

Compound 3, half-maximal effective concentration: > 20000 nM
Compound 3 was reported as a limit (the forecaster's own chance of this, stated with the estimate: 60%); the middle value lies beyond the limit too.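

In this assay compound 3 gives > 20000 nM as a limit, so no step from compound 2 to compound 3 can be read: the limit of > 20000 nM in this assay, at which 2 of the 3 values shown sit.

Going by these compounds, the size and direction of the change from 4-isopropylphenyl to 2,3-dihydro-1,4-benzodioxin-6-yl in this assay remain open.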